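A few compounds are considered here, and "the series" means these few. Any claim that something is new, unique, unknown or untested is made for them only; others in the source may bear on it.

Measured so far in an assay for inhibition of Fatty-acid amide hydrolase 1 (Rattus norvegicus); a lower number here means a stronger inhibitor, a higher number a weaker inhibitor:
compound 1 `CN(C)C(=O)c1cnc(C(=O)CCc2ccc(Oc3ccccc3)cc2)o1` gives 5.4 nM
compound 2 `O=C(O)c1cc(-c2cnc(C(=O)CCc3ccc(-c4ccccc4)cc3)o2)ccn1` gives 50 nM
compound 3 `O=C(O)c1ccc(-c2cnc(C(=O)CCc3ccc(-c4ccccc4)cc3)o2)nc1` gives 14 nM

On these numbers compound 3 sits second highest, with compound 1 nearest and lower, and compound 2 furthest and higher. Among the compounds with values here, the single measured step, a 3.6-fold lower number from compound 2 to compound 3 (0.55 log units; beyond the scatter), concerns the carboxypyridyl group and not the exchange now at hand. Compound 4 `O=C(O)c1ccc(-c2cnc(C(=O)CCc3ccc(Oc4ccccc4)cc3)o2)nc1` carries the change (phenoxy in place of phenyl on an aromatic carbon). Within the data shown here, no measured step bears on this exchange: compound 1 holds the phenoxy group but differs from compound 3 in two places, so the values of compound 1 and compound 3 show only that the phenoxy-bearing compound lies lower. With nothing directly comparable, the expected step of a 1.4-fold lower number from compound 3 to compound 4 (0.15 log units; within the scatter) is small, a move downward that may not exceed the scatter. Compound 4 is therefore estimated at 10 nM in this assay, within 3 nM to 40 nM.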

Compound 4, inhibition constant: 33 nM
Beside the measured number, compound 4's estimate is 3.3-fold (0.52 log units) below it; the range from low to high includes it.
By their numbers in this assay, from the lowest: compound 1; then compound 3; then compounds 4 and 2 (each within the scatter of the next).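

In this assay, phenoxy in place of phenyl on an aromatic carbon para to a large group gives a 2.4-fold higher number from compound 3 to compound 4 (0.37 log units; beyond the scatter) and so weakens inhibition in the carboxypyridine setting. With phenoxy held constant, 5-carboxypyridin-2-yl in place of dimethylcarbamoyl gives a 6.1-fold higher number from compound 1 to compound 4 (0.79 log units; beyond the scatter) and leaves the dimethylcarbamoyl compound the stronger inhibitor of this pair. No evidence on hand accounts for either step.

Open, going by these compounds, is whether the phenoxy-for-phenyl step holds with dimethylcarbamoyl or 2-carboxypyridin-4-yl on the core. Also open, on these data alone, is how a benzyloxy group or an amine would read at that place.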